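This account rests on a few compounds, and the source may have more. Where it says the series, first, only, none or still open, it means among the compounds named here.

In a functional assay on A375P cells (Homo sapiens) for antiproliferative activity (a higher number here means a weaker inhibitor, a lower number a stronger inhibitor), compound 1 `CC(=O)Nc1cc(NC(=O)Nc2ccc(Cl)c(Cl)c2)ccc1C` gives 2100 nM. Compound 2 `Cc1ccc(NC(=O)Nc2ccc(Cl)c(Cl)c2)cc1NC(=O)c1ccccc1` gives 5800 nM, and compound 3 `Cc1ccc(NC(=O)Nc2ccc(Cl)c(C(F)(F)F)c2)cc1NC(=O)c1ccccc1` gives 1300 nM. Compound 2 therefore has the highest half-maximal inhibitory concentration of the three: the step of a 2.8-fold higher number from compound 1 to compound 2 (0.44 log units; beyond the scatter) raised the number, and the step of a 4.5-fold lower number from compound 2 to compound 3 (0.65 log units; beyond the scatter) brought it down again. Compound 4 `Cc1ccc(NC(=O)Nc2ccc3c(c2)OCCO3)cc1NC(=O)c1ccccc1` differs from compound 2 in one place: 2,3-dihydro-1,4-benzodioxin-6-yl in place of 3,4-dichlorophenyl on an amide-type nitrogen. Among the measured compounds shown here, of the two measured steps, only the one from compound 2 to compound 3 touches the same ring, and it swapped a single substituent rather than the whole ring; the step from compound 1 to compound 2 alters a different part of the shared core and says nothing about this ring. For the measured compounds named here, no measured pair exchanges the entire aryl group, so the change is without direct precedent here. Compound 4 is expected to shift by a modest step in this assay, more likely toward a higher number, and the expected step is a 1.6-fold higher number from compound 2 to compound 4 (0.19 log units; within the scatter). Compound 4 is estimated at 9000 nM, within a range of 3000 nM to 30000 nM.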

Compound 4, half-maximal inhibitory concentration: > 30000 nM
Compound 4: no number, only a limit (the forecaster's own chance of this, stated with the estimate: 15%); at least 3.3-fold (0.52 log units) between middle value and limit.
By their numbers in this assay, from the lowest: compounds 3 and 1 (each within the scatter of the next); then compound 2. At a limit, above all of these: compound 4.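

Among the compounds shown here, the exchange of 3,4-dichlorophenyl for 2,3-dihydro-1,4-benzodioxin-6-yl on the amide-type nitrogen gives an at least 5.1-fold higher number from compound 2 to compound 4 (0.71 log units; beyond the scatter) in this assay, the first step here that replaces the whole aryl group rather than one substituent on it. This step runs opposite to a 4.5-fold lower number from compound 2 to compound 3 (0.65 log units; beyond the scatter), so changes to this aryl group can move the number beyond the scatter in either direction. Compound 4 stands at a limit of the assay rather than at a number, so this step has a lower bound but no measured size: the limit of > 30000 nM in this assay, at which 1 of the 4 values shown sits.

The compounds shown leave open whether the rise follows from losing the two chlorines or from gaining the two ring oxygens of the entering group. A phenyl ring carrying a single methoxy group or a single fluorine could help separate those two changes.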